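The source may report more compounds than this note shows. Statements on the series, on what has been measured and on what is new or still open speak of the compounds shown alone.

In a functional assay on MIA PaCa-2 cells (Homo sapiens) for antiproliferative activity, read by MTT assay, with a stated time of 24 h (on this read-out lower numbers stand for stronger inhibition and higher numbers for weaker inhibition), compound 1 (`c1ccc(-c2noc(-c3ccncc3)n2)cc1`) gives 497000 nM. Compound 2 (`COc1ccc(-c2noc(-c3ccncc3)n2)cc1OC1CCCC1`) gives 9330 nM, level within the scatter with compound 3 (`COc1ccc(-c2noc(Cc3c[nH]c4ccccc34)n2)cc1OC1CCCC1`) at 9560 nM. Both lie well below compound 1, beyond the scatter. Compound 4 (`COc1ccc(-c2noc(-c3ccc(F)cc3)n2)cc1OC1CCCC1`) differs from compound 2 by 4-fluorophenyl in place of pyridin-4-yl on an aromatic carbon. For the measured compounds named here, no measured pair isolates this change. Compound 3 carries a different group on that same carbon and gives 9560 nM, which points to a small step at most. The estimated step of a 1.3-fold lower number from compound 2 to compound 4 (0.12 log units; within the scatter) is expected to stay within the scatter. For compound 4 the expected value is 7000 nM, with an estimated range of 2000 nM to 25000 nM.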

Compound 4, half-maximal inhibitory concentration: 6090 nM
For compound 4 the middle estimate is 1.1-fold (0.06 log units) above the measured one; measured number inside the range.
By their numbers in this assay, from the lowest: compounds 4, 2 and 3 (each within the scatter of the next); then compound 1.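

For the compounds shown here, this is the first step that isolates a change at this position. In this assay, 4-fluorophenyl in place of pyridin-4-yl gives a 1.5-fold lower number from compound 2 to compound 4 (0.19 log units; within the scatter), so the ring nitrogen and the hydrogen-bond acceptor counted on pyridin-4-yl are not required to keep the read-out at this level. Nothing available accounts for this result.

Open, on these data alone, is how a carboxylic acid or an amine on this carbon would read. Also open, as far as these compounds go, is whether plain phenyl would match 4-fluorophenyl here.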